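Propylamino in place of chloromethyl: an untested step

This account rests on a few compounds, and the source may have more. Where it says the series, first, only, none or still open, it means among the compounds named here.

In a functional assay for inhibition, with Homo sapiens as the target (on this read-out higher numbers stand for an effect only at larger amounts of compound and lower numbers for an effect already at smaller amounts), compound 1 `CCC(=O)Nc1ccc(C2=NNC(=O)CC2)cc1` gives 0.64 ug/mL, compound 2 `CC(Cl)C(=O)Nc1ccc(C2=NNC(=O)CC2)cc1` gives 0.45 ug/mL and compound 3 `O=C1CCC(c2ccc(NC(=O)CCCl)cc2)=NN1` gives 0.98 ug/mL. Compound 3 thus stands at the high-number end of this small set, level with compound 1 within the scatter: a 1.5-fold higher number from compound 1 to compound 3 (0.19 log units; within the scatter). Only a 2.2-fold higher number from compound 2 to compound 3 (0.34 log units; beyond the scatter) goes beyond the scatter, and that step is modest.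

Compound 4 `CCCNCC(=O)Nc1ccc(C2=NNC(=O)CC2)cc1` carries propylamino in place of chloromethyl on a saturated chain carbon bound to a carbonyl carbon. The measured steps that bear on this change all concern the chloro group on the same chain. Besides the two above, there is a 1.4-fold lower number from compound 1 to compound 2 (0.15 log units; within the scatter), which also stays within the scatter. None of them brings in propylamino, so they offer only a rough guide.

Going by their small size, no step beyond the scatter is expected in this assay, and the estimated step is a 1.3-fold lower number from compound 3 to compound 4 (0.12 log units; within the scatter). Compound 4 is expected at about 0.75 ug/mL, with an estimated range from 0.25 ug/mL to 2.2 ug/mL.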

Compound 4, half-maximal effective concentration: about 46.4 ug/mL
Beside the measured number, compound 4's estimate is 62-fold (1.79 log units) below it, outside the stated range (above it).
By their numbers in this assay, from the lowest: compounds 2, 1 and 3 (each within the scatter of the next, the first and the last beyond it); then compound 4.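

In this assay, the chloro changes on this chain gave only small steps, but this position is not indifferent to every group: propylamino in place of chloromethyl on a saturated chain carbon bound to a carbonyl carbon gives a 47-fold higher number from compound 3 to compound 4 (1.68 log units; beyond the scatter). The other two comparisons point the same way, with propylamino in place of methyl at that place giving a 73-fold higher number from compound 1 to compound 4 (1.86 log units; beyond the scatter) and (propylamino)methyl in place of 1-chloroethyl on a carbonyl carbon giving a 100-fold higher number from compound 2 to compound 4 (2.01 log units; beyond the scatter). Nothing available here offers an explanation for these large steps.

Open is whether the shift follows the amine nitrogen or the propyl chain, as only one amine appears among these compounds. A smaller amine such as methylamino, a tertiary amine such as dimethylamino, or a propoxy ether, with oxygen in place of that nitrogen, would help to separate the two.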